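From fluoro to tert-butyl on the aromatic ring

This account rests on a few compounds, and the source may have more. Where it says the series, first, only, none or still open, it means among the compounds named here.

Measured in a functional assay on A549 cells (Homo sapiens) for antiproliferative activity, read by MTT assay, with a stated time of 72 h; a higher number here means a weaker inhibitor, a lower number a stronger inhibitor:
- compound 1 `NC1=NC2(CCOCC2)N(OCCCOc2ccc(F)cc2)C(N)=N1` gives 1060 nM
- compound 2 `NC1=NC2(CCOCC2)N(OCCCOc2cc(Cl)c(Cl)cc2Cl)C(N)=N1` gives 680 nM
- compound 3 `NC1=NC2(CCOCC2)N(OCCCOc2ccccc2Br)C(N)=N1` gives 160 nM

Compound 1 stands at the weak end of this set, level with compound 2 (a 1.6-fold lower number from compound 1 to compound 2 (0.19 log units; within the scatter)). Compound 4 `CC(C)(C)c1ccc(OCCCON2C(N)=NC(N)=NC23CCOCC3)cc1` keeps the rest of compound 1 but has tert-butyl in place of fluoro on an aromatic carbon, para to a large group (tert-butyl in place of fluoro on an aromatic carbon). Among the compounds with values here, no measured compound carries tert-butyl, so the only guides are two other exchanges of the aromatic group: the step just given, and a larger one (a 6.6-fold lower number from compound 1 to compound 3 (0.82 log units; beyond the scatter)). Neither raised the number. Expected in this assay is a small move to a lower number (a 2.0-fold lower number from compound 1 to compound 4 (0.31 log units; beyond the scatter)). For compound 4 the estimated value is 520 nM (expected range 170 nM to 1500 nM).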

Compound 4, half-maximal inhibitory concentration: 500 nM
Beside the measured number, compound 4's estimate is 1.0-fold (0.02 log units) above it; low and high end bracket the measured number.
By their numbers in this assay, from the lowest: compound 3; then compounds 4, 2 and 1 (each within the scatter of the next, the first and the last beyond it).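

In this assay this exchange alters a single group on the aromatic ring, on an aromatic carbon para to a large group, and the number falls (a 2.1-fold lower number from compound 1 to compound 4 (0.33 log units; beyond the scatter)). At this place, then, the larger tert-butyl does not raise the number compared with fluoro, although neither group adds a ring, a charge or a hydrogen-bond donor or acceptor. Nothing available explains why the number falls.

On these data alone, how an amine or a carboxylic acid at this same place would compare remains open.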